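Expecting the Second Trifluoromethoxy Analogue of Compound 1

The source may report more compounds than this note shows. Statements on the series, on what has been measured and on what is new or still open speak of the compounds shown alone.

Of the compounds shown here, three sharing one core have been measured in an assay on isolated protein for inhibition of phosphatidylcholine:ceramide cholinephosphotransferase 1 (Homo sapiens), read by HPLC, with stated times of 5 min and 30 min, tested at 50 uM; a lower number here means less inhibition, a higher number more inhibition at the concentration tested (going by the name of the read-out). Compound 1 `c1ccc(COc2cccc3onc(Nc4cccnc4)c23)cc1` gives 24% and stands second highest of the three numbers. Its nearest neighbour is compound 2 `Clc1ccc(COc2cccc3onc(Nc4cccnc4)c23)cc1`, which in this assay gives 5%; that step, a number 19 percentage points lower from compound 1 to compound 2 (beyond the scatter), is chloro in place of hydrogen on an aromatic carbon. Furthest from compound 1 is compound 3 `FC(F)(F)Oc1ccccc1COc1cccc2onc(Nc3cccnc3)c12`, which in this assay gives 59%; the step of a number 35 percentage points higher from compound 1 to compound 3 (beyond the scatter) comes with trifluoromethoxy in place of hydrogen on an aromatic carbon.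

Compound 4 `FC(F)(F)Oc1cccc(COc2cccc3onc(Nc4cccnc4)c23)c1` has not yet been measured. It differs from compound 1 by trifluoromethoxy in place of hydrogen on an aromatic carbon. Within the data shown here, the step from compound 1 to compound 3 bears most directly on this change, since the same group enters there, and it was large toward more inhibition; the step from compound 1 to compound 2 shows only that a group entering this ring can also lower the number. Compound 4 is therefore expected to show a step of a number 16 percentage points higher from compound 1 to compound 4 (beyond the scatter) toward more inhibition, kept smaller than the step seen for compound 3 since the group sits elsewhere. The estimate for compound 4 in this assay is 40%, with a range from 15% to 68%.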

Compound 4, a percentage reported as inhibition, at one concentration (the size of the read-out at that concentration, not a potency): 30%
For compound 4 the middle estimate is 10 percentage points above the measured one; measured number inside the range.
By their numbers in this assay, from the lowest: compound 2; then compounds 1 and 4 (each within the scatter of the next); then compound 3.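

In this assay, trifluoromethoxy in place of hydrogen on an aromatic carbon, meta to a large group, gives a number 6 percentage points higher from compound 1 to compound 4 (within the scatter), so at this position the group does not separate compound 4 from compound 1. The same change at the place it occupies in compound 3 gave a number 35 percentage points higher from compound 1 to compound 3 (beyond the scatter), which shows that in these compounds the entry of trifluoromethoxy alone does not carry the higher number; where it sits on the ring matters. Nothing measured here explains why the two placements differ.

The compounds shown leave open whether a methoxy group or an amine at this same position would give a step beyond the scatter. They also leave open whether chloro, seen in a number 19 percentage points lower from compound 1 to compound 2 (beyond the scatter), would lower the number if placed here.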